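Pyridyl for phenyl on the shared core: expected cytotoxicity shift

The compounds below may be only part of what the source reports. "The series", "measured", "known", "first", "only" and "open" are said of these compounds alone.

Going by the values given here, compound 3 `Oc1ccc(-c2cc(-c3ccccc3)nc(-c3ccc(Cl)cc3)c2)cc1` gives 4810 nM in an ADME assay on HEK293 cells (Homo sapiens) for cytotoxicity, read by CCK-8 assay and cell counting, with a stated time of 2 days (a higher number here means a weaker inhibitor, a lower number a stronger inhibitor), the lowest of the three numbers so far; compound 2 `Oc1cccc(-c2cc(-c3ccc(Cl)cc3)nc(-c3ccccn3)c2)c1` gives 14000 nM and compound 1 `Oc1ccc(-c2cc(-c3ccc(Cl)cc3)nc(-c3cccnc3)c2)cc1` gives 27500 nM. Compound 4 `Oc1ccc(-c2cc(-c3ccc(Cl)cc3)nc(-c3ccccn3)c2)cc1` differs from compound 3 by pyridin-2-yl in place of phenyl on an aromatic carbon. Among the compounds with values here, the one measured step that bears on this exchange runs the other way: a 5.7-fold lower number from compound 1 to compound 3 (0.76 log units; beyond the scatter). Compound 2 carries the same pyridin-2-yl group with a 3-hydroxyphenyl group and sits above compound 3. Reversing the phenyl-for-pyridyl step, a higher number is expected for compound 4, with a 3.7-fold higher number from compound 3 to compound 4 (0.57 log units; beyond the scatter) as the estimated step. Compound 4 is therefore expected at about 18000 nM, within 7000 nM to 45000 nM.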

Compound 4, half-maximal inhibitory concentration: 27200 nM
Beside the measured number, compound 4's estimate is 1.5-fold (0.18 log units) below it; the range from low to high includes it.
By their numbers in this assay, from the lowest: compound 3; then compounds 2, 4 and 1 (each within the scatter of the next).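

In this assay, pyridin-2-yl in place of phenyl gives a 5.7-fold higher number from compound 3 to compound 4 (0.75 log units; beyond the scatter), so the direct exchange at this position now shows the same gap that the pyridin-3-yl pair suggested. Pyridin-2-yl in place of pyridin-3-yl gives a 1.0-fold lower number from compound 1 to compound 4 (0.00 log units; within the scatter), so these two pyridyl groups are not told apart here. 4-hydroxyphenyl in place of 3-hydroxyphenyl gives a 1.9-fold higher number from compound 2 to compound 4 (0.29 log units; within the scatter), which also does not separate them.

On these data alone, whether a pyridin-4-yl or an aminophenyl group at this position would read with the phenyl or the pyridyl compounds stays open. No measurement on hand explains the gap between phenyl and the pyridyl groups.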